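Adding a Carboxymethyl Arm to the Best-Tolerated Amide

This account rests on a few compounds, and the source may have more. Where it says the series, first, only, none or still open, it means among the compounds named here.

Of the compounds shown here, three built on one shared core have been measured in an ADME assay on MDBK cells (Bos taurus) for cytotoxicity, read by MTT assay, with a stated time of 96 h; a lower number here means that less compound is tolerated, a higher number that more compound is tolerated. Compound 1 `CC(=O)Nc1ccc(-c2nc3cc(C(F)(F)F)ccc3n2C2CCCCC2)cc1` gives 17000 nM, compound 2 `O=C(CN1CCCC1)Nc1ccc(-c2nc3cc(C(F)(F)F)ccc3[nH]2)cc1` gives 15000 nM, and compound 3 `CC(=O)Nc1ccc(-c2nc3cc(C(F)(F)F)ccc3[nH]2)cc1` gives 50000 nM, which makes compound 3 the highest of the three numbers, that is, the compound the cells tolerate best. Both measured steps that arrive at compound 3 strip a group away: a 2.9-fold higher number from compound 1 to compound 3 (0.47 log units; beyond the scatter) and a 3.3-fold higher number from compound 2 to compound 3 (0.52 log units; beyond the scatter). Each removal therefore raised the number by a modest amount.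

Compound 4 `O=C(O)CCC(=O)Nc1ccc(-c2nc3cc(C(F)(F)F)ccc3[nH]2)cc1` runs the other way, adding to compound 3: carboxymethyl in place of hydrogen on a saturated chain carbon bound to a carbonyl carbon. Among the measured compounds shown here, no measured step adds a carboxymethyl, so the closest guide is the step at the same place, a 3.3-fold higher number from compound 2 to compound 3 (0.52 log units; beyond the scatter), in which a group removed there gave a modest rise. Reading that backwards, adding a group at the same place is expected to give a modest fall, although a different group may behave differently, so the expected step of a 1.4-fold lower number from compound 3 to compound 4 (0.15 log units; within the scatter) is small and could stay within the scatter. On that basis compound 4 is estimated at 35000 nM in this assay, with a likely range from 15000 nM to 90000 nM.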

Compound 4, half-maximal cytotoxic concentration: > 100000 nM
Compound 4: no number, only a limit; the forecaster's own chance of this, stated with the estimate: 20%; at least 2.8-fold (0.45 log units) between middle value and limit.
By their numbers in this assay, from the lowest: compounds 2 and 1 (each within the scatter of the next); then compound 3. At a limit, above all of these: compound 4.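

Among the compounds shown here, at the saturated chain carbon bound to a carbonyl carbon, the earlier compounds showed only that taking a group away raised the number, which left open whether any added group there would lower it in this assay. Carboxymethyl in place of hydrogen brings no such fall, giving an at least 2.0-fold higher number from compound 3 to compound 4 (0.30 log units; that floor lies within the scatter), and exchanging one group for another at the same place gives an at least 6.6-fold higher number from compound 2 to compound 4 (0.82 log units; beyond the scatter), so what sits at this carbon counts, not merely whether something does. Compound 4 gives > 100000 nM, which is a limit and not a number, and both steps are floors for that reason: the limit of > 100000 nM in this assay, at which 1 of the 4 values shown sits.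

The compounds shown cannot separate the acid end of the 2-carboxyethyl arm from its length: a methyl ester or a plain propyl chain at this place would speak to that, and a longer chain ending in a carboxylic acid would show whether the high number holds. Also open, on these data alone, is how the same arm behaves in a compound that carries cyclohexyl on the aromatic nitrogen.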